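One Ring Centre Inverted: Expecting Compound 3

The source may report more compounds than this note shows. Statements on the series, on what has been measured and on what is new or still open speak of the compounds shown alone.

In an assay on HEK293 cells for antagonist activity at transient receptor potential cation channel subfamily V member 3 (Homo sapiens), read by FLIPR and calcium flux (on this read-out lower numbers stand for stronger inhibition and higher numbers for weaker inhibition), compound 2 `C[C@@]1(c2ccc(OC(F)(F)F)cc2)C[C@](O)(c2ccccn2)CO1` gives 1710 nM. Its mirror image, compound 1 `C[C@]1(c2ccc(OC(F)(F)F)cc2)C[C@@](O)(c2ccccn2)CO1`, gives 2460 nM in this assay; the step of a 1.4-fold lower number from compound 1 to compound 2 (0.16 log units; within the scatter) lies within the scatter, so the two stand on a par and compound 2 is not set apart by the numbers shown. Compound 3 `C[C@]1(c2ccc(OC(F)(F)F)cc2)C[C@](O)(c2ccccn2)CO1` differs from compound 2 by the two compounds have the same atoms and bonds and differ only in configuration as drawn: 1 of 2 stereo elements differ; a stereocentre at a saturated ring carbon is drawn S in compound 2 and R in compound 3, which makes compound 3 a diastereomer of compound 2 rather than a mirror image. Within the data shown here, the only measured step, a 1.4-fold lower number from compound 1 to compound 2 (0.16 log units; within the scatter), inverts both centres at once and stays within the scatter; it offers no guidance on what inverting one centre alone does. The expectation is therefore no step beyond the scatter, held with wide uncertainty: compound 3 is expected to give 2000 nM in this assay, within 500 nM to 8000 nM. That expected step, a 1.2-fold higher number from compound 2 to compound 3 (0.07 log units; within the scatter), rests on compound 2 alone.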

Compound 3, antagonist equilibrium constant: 420 nM
Beside the measured number, compound 3's estimate is 4.8-fold (0.68 log units) above it; measured number below the stated range.
By their numbers in this assay, from the lowest: compound 3; then compounds 2 and 1 (each within the scatter of the next).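

In this assay, the mirror-image pair gave no sign that configuration matters on this core, but inverting one ring centre alone does show an effect: a 4.1-fold lower number from compound 2 to compound 3 (0.61 log units; beyond the scatter), and a 5.9-fold lower number from compound 1 to compound 3 (0.77 log units; beyond the scatter). Compound 3 is therefore the strongest inhibitor of the three, while compound 1 and compound 2 stay on a par, so the way the two centres are arranged relative to each other matters more here than the overall mirror-image form of the pair. The gap can be put down to configuration alone, because no atom or bond changes: the fact that compounds 2 and 3 differ only in the configuration as drawn

Going by these compounds, how the mirror image of compound 3 would compare remains open, and it would show whether this gain holds for both mirror forms of this arrangement. On these data alone, all three compounds carry the same groups, so it is also open whether an amine in place of the hydroxyl would keep the same preference.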